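Bromo to phenyl on the pendant aryl of compound 2

The source may report more compounds than this note shows. Statements on the series, on what has been measured and on what is new or still open speak of the compounds shown alone.

Compound 1 `O=C(N1CCC=C[C@@H]1COCc1ccccc1)n1cc(-c2ccc(Oc3ccccc3)cc2)nn1` gives 25.1 nM in an assay on HEK293 cells for inhibition of diacylglycerol lipase-alpha (Homo sapiens), read by colorimetric assay, with stated times of 30 min, 60 s and 20 min; a higher number here means a weaker inhibitor, a lower number a stronger inhibitor. Compound 2 `O=C(N1CCC=C[C@@H]1COCc1ccccc1)n1ccc(-c2ccc(Br)cc2)n1` reaches only the assay limit, > 10000 nM, in this assay. Compound 3 `O=C(N1CCC=C[C@@H]1COCc1ccccc1)n1cnc(-c2ccc(Br)cc2)c1` likewise sits at the limit, > 10000 nM. Compound 2 therefore stands at the limit of > 10000 nM in this assay, at which 2 of the 3 values shown sit, with no number of its own. Compound 4 `O=C(N1CCC=C[C@@H]1COCc1ccccc1)n1ccc(-c2ccc(-c3ccccc3)cc2)n1` differs from compound 2 by phenyl in place of bromo on an aromatic carbon; phenyl in place of bromo on an aromatic carbon, para to a large group. Among the compounds with values here, no measured step anchors this change. With compound 2 at the limit, the step from compound 2 to compound 4 is expected to be small and its direction uncertain, an at least 1.2-fold lower number from compound 2 to compound 4 (0.09 log units; that floor lies within the scatter), with a fair chance that only a limit is reported again. Compound 4 is expected to give about 8000 nM, within 1000 nM to 30000 nM.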

Compound 4, half-maximal inhibitory concentration: > 10000 nM
Compound 4: a limit, no number; the forecaster's own chance of this, stated with the estimate: 60%; middle value at least 1.2-fold (0.09 log units) from the limit.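

Compound 2 and compound 4 both return only a limit, so no step between them can be read: the limit of > 10000 nM in this assay, at which 3 of the 4 values shown sit.

Still open, on these data alone, is whether phenyl in place of bromo on an aromatic carbon changes inhibition at all.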